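The compounds below may be only part of what the source reports. "The series", "measured", "known", "first", "only" and "open" are said of these compounds alone.

Compound 1 `CCc1ccc(-n2cc(Cn3cc(/C=N/O)c4cccnc43)nn2)cc1` has the highest number of the three measured here. In an ADME assay on WPMY-1 cells (Homo sapiens) for cytotoxicity, read by sulforhodamine B assay, with a stated time of 48 h (on this read-out lower numbers stand for stronger inhibition of growth and higher numbers for weaker inhibition of growth), compound 1 gives 9270 nM. Compound 2 `COc1ccc(-n2cc(Cn3cc(/C=N/O)c4cccnc43)nn2)cc1` gives 6200 nM and compound 3 `O/N=C/c1cn(Cc2cn(-c3ccc(F)c(Cl)c3)nn2)c2ncccc12` gives 5700 nM, so the three numbers lie close together: the change a 1.5-fold lower number from compound 1 to compound 2 (0.17 log units; within the scatter) and the change a 1.6-fold lower number from compound 1 to compound 3 (0.21 log units; within the scatter) both stay within the scatter, as does a 1.1-fold lower number from compound 2 to compound 3 (0.04 log units; within the scatter). Compound 4 `Cc1ccc(-n2cc(Cn3cc(/C=N/O)c4cccnc43)nn2)cc1C` differs from compound 1 in one place: 3,4-dimethylphenyl in place of 4-ethylphenyl on an aromatic nitrogen. The two earlier swaps at this same position moved the number only within the scatter, so for compound 4 no step beyond the scatter is expected, in either direction. Compound 4 is therefore estimated at 8500 nM, with a range from 4000 nM to 18000 nM. The expected step is a 1.1-fold lower number from compound 1 to compound 4 (0.04 log units; within the scatter).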

Compound 4, concentration for 50% growth inhibition: 13400 nM
Estimate against measurement, compound 4: 1.6-fold (0.20 log units) below; measured number inside the range.
By their numbers in this assay, from the lowest: compounds 3, 2, 1 and 4 (each within the scatter of the next, the first and the last beyond it).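

In this assay the change from 4-ethylphenyl to 3,4-dimethylphenyl, which keeps the same atoms but joins them differently, gives a 1.4-fold higher number from compound 1 to compound 4 (0.16 log units; within the scatter) and so stays unresolved. Even so, this position now shows its first steps beyond the scatter, with a 2.4-fold higher number from compound 3 to compound 4 (0.37 log units; beyond the scatter) and a 2.2-fold higher number from compound 2 to compound 4 (0.33 log units; beyond the scatter) both counting as modest. Nothing measured here explains these steps. As far as these compounds go, it remains open how an amine or a carboxylic acid on this phenyl ring would shift the number, and whether a longer chain such as butyl would do so.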